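The source may report more compounds than this note shows. Statements on the series, on what has been measured and on what is new or still open speak of the compounds shown alone.

Compound 2 `O=C1CCC(N2C(=O)c3ccc(Nc4ccccc4)cc3C2=O)C(=O)N1` gives 6% in an assay on FRT-Jurkat cells for inhibition of nuclear factor NF-kappa-B complex (Homo sapiens), read by flow cytometry, with a stated time of 24 h, tested at 10 uM (on this read-out higher numbers stand for more inhibition at the one concentration tested (going by the name of the read-out) and lower numbers for less inhibition), and of the two numbers available it stands alongside compound 1 `CCOC(=O)c1ccc(Nc2ccc3c(c2)C(=O)N(C2CCC(=O)NC2=O)C3=O)cc1`, which gives 5% in this assay, the two lying within the usual scatter of each other. For the measured compounds named here, the only measured step, a number 1 percentage points higher from compound 1 to compound 2 (within the scatter), replaces ethoxycarbonyl with hydrogen on an aromatic carbon and shifts the read-out by nothing that can be told from noise. Compound 3 `CC(C)c1ccc(Nc2ccc3c(c2)C(=O)N(C2CCC(=O)NC2=O)C3=O)cc1` differs from compound 2 by isopropyl in place of hydrogen on an aromatic carbon. Going by the values given here, the only step that bears on this substitution of a group onto that aromatic carbon is a number 1 percentage points higher from compound 1 to compound 2 (within the scatter), which was small, so a change in the opposite sense, putting a group in where hydrogen stood, is expected to move the number little as well. The expected step is therefore a number 1 percentage points higher from compound 2 to compound 3 (within the scatter), no more than the scatter. Compound 3 is thus estimated at 7% in this assay, within a range of 0% to 20%.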

Compound 3, a percentage reported as inhibition, at one concentration (the size of the read-out at that concentration, not a potency): 11%
Compound 3: the middle estimate sits 4 percentage points below what was measured; the measured number falls inside the stated range.
By their numbers in this assay, from the lowest: compounds 1, 2 and 3 (each within the scatter of the next).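

Placing isopropyl on the aromatic carbon para to a large group, which turns phenyl into 4-isopropylphenyl, gives a number 5 percentage points higher from compound 2 to compound 3 (within the scatter) in this assay and so adds a second substituent whose step from the unsubstituted compound stays inside the scatter. Exchanging one substituent directly for the other gives a number 6 percentage points higher from compound 1 to compound 3 (within the scatter) and also stays inside the scatter, so ethoxycarbonyl, isopropyl and hydrogen cannot be told apart at this position on this read-out. Nothing available explains why these numbers lie where they do.

The compounds shown leave open whether an amine, a carboxylic acid or a longer chain at this same carbon would produce a step beyond the scatter. They also leave open how a change elsewhere on the shared core would register.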